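Morpholinylmethyl for oxanyl on the amide chain

A few compounds are considered here, and "the series" means these few. Any claim that something is new, unique, unknown or untested is made for them only; others in the source may bear on it.

Series of three measured pyridone-type amides on a shared core; compound 1 is `CNC(=O)c1cc(C(=O)NC2CC2)cn(Cc2cccc(OC)c2)c1=O`, compound 2 is `CNC(=O)c1cc(C(=O)NC2CCC2)cn(Cc2cccc(NC)c2)c1=O`, compound 3 is `CNC(=O)c1cc(C(=O)NCCC2CCOCC2)cn(Cc2ccccc2)c1=O`. In a physicochemical assay for lipophilicity, at pH 7.4 (on this read-out lower numbers stand for lower lipophilicity and higher numbers for higher lipophilicity), compound 1 gives 3. In this assay compound 2 gives 3.6. In this assay compound 3 gives 3.6, level with compound 2 within the scatter; together these two stand highest of the three numbers, and compound 1 sits lower by a margin beyond the scatter. For the measured compounds named here, no pair among them differs in one place only, so no single-change step is available.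

Compound 4 is `CNC(=O)c1cc(C(=O)NCCCC2CNCCO2)cn(Cc2ccccc2)c1=O`. It differs from compound 3 by (morpholin-2-yl)methyl in place of oxan-4-yl on a saturated chain carbon, two bonds along the chain from an amide-type nitrogen. The entering group carries 1 hydrogen-bond donor and 2 hydrogen-bond acceptors where the leaving group carried 0 hydrogen-bond donors and 1 hydrogen-bond acceptor. For compound 4 the expected step is a number 1.60 log units lower from compound 3 to compound 4 (beyond the scatter). Compound 4 is estimated at 2, within 1.2 to 2.8.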

Compound 4, distribution coefficient: 1.4
The estimate for compound 4 lay 0.60 log units above the measured number, and the stated range covers the measured number.
By their numbers in this assay, from the lowest: compound 4; then compound 1; then compounds 2 and 3 (each within the scatter of the next).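

In this assay, for the compounds shown here, (morpholin-2-yl)methyl in place of oxan-4-yl on a saturated chain carbon, two bonds along the chain from an amide-type nitrogen, gives the first single-change step: a number 2.20 log units lower from compound 3 to compound 4 (beyond the scatter), a large step. The earlier compounds shown here differ in more than one place, so they could not tie any shift to this chain; this pair shows that a change here alone can move the read-out well beyond the scatter. No measurement shown bears on the cause of this step.

The step combines a different ring, with its added ring nitrogen, and the added methyl link, and the pair cannot divide the shift between them. A (oxan-2-yl)methyl group or a (4-methylmorpholin-2-yl)methyl group at this place would separate these contributions.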